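A few compounds are considered here, and "the series" means these few. Any claim that something is new, unique, unknown or untested is made for them only; others in the source may bear on it.

Measured so far in an assay on liver for inhibition of sterol O-acyltransferase 1 (Rattus norvegicus), using microsomes; a higher number here means a weaker inhibitor, a lower number a stronger inhibitor:
compound 1 `Cc1cc(C(C)(C)C)c(OC(=O)NS(=O)(=O)N(C(C)C)C(C)C)c(C(C)(C)C)c1`: 3200 nM
compound 2 `CCCCCCNS(=O)(=O)NC(=O)Oc1c(C(C)(C)C)cc(C)cc1C(C)(C)C`: 19400 nM
compound 3 `CCCCCN(CCCCC)S(=O)(=O)NC(=O)Oc1c(C(C)(C)C)cc(C)cc1C(C)(C)C`: 2200 nM

Compound 2 stands at the highest number of the three, with compound 1 nearest at a 6.1-fold higher number from compound 1 to compound 2 (0.78 log units; beyond the scatter) and compound 3 furthest at an 8.8-fold lower number from compound 2 to compound 3 (0.95 log units; beyond the scatter); both gaps lie beyond the scatter. The shared core carries a sulfamoylcarbamate, and the three compounds differ only in what sits on the sulfonyl sulfur.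

Compound 4 `CCCCCCN(CCCCCC)S(=O)(=O)NC(=O)Oc1c(C(C)(C)C)cc(C)cc1C(C)(C)C` is not yet measured. It differs from compound 2 as follows: hexyl in place of hydrogen on a sulfonamide nitrogen. The result is a dihexylamino group on the sulfonyl sulfur.

Within the data shown here, two measured steps bear on this. From compound 2 to compound 3, hexylamino became dipentylamino, giving an 8.8-fold lower number from compound 2 to compound 3 (0.95 log units; beyond the scatter). From compound 1 to compound 2, diisopropylamino became hexylamino, giving a 6.1-fold higher number from compound 1 to compound 2 (0.78 log units; beyond the scatter). In both, the compound with a single chain on the sulfonamide nitrogen sits at the higher number, and the two dialkyl compounds 1 and 3 lie within the scatter of each other. Filling the second position of the nitrogen in compound 2 with a second hexyl is therefore expected to lower the number by a modest amount, close to what the step to compound 3 showed.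

Estimated step: a 7.8-fold lower number from compound 2 to compound 4 (0.89 log units; beyond the scatter). Compound 4 is estimated at 2500 nM in this assay, with a range from 900 nM to 7000 nM.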

Compound 4, half-maximal inhibitory concentration: 4300 nM
Estimate against measurement, compound 4: 1.7-fold (0.24 log units) below; the range from low to high includes it.
By their numbers in this assay, from the lowest: compounds 3, 1 and 4 (each within the scatter of the next); then compound 2.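

In this assay, among these compounds, the step with hexyl in place of hydrogen on the sulfonamide nitrogen gives a 4.5-fold lower number from compound 2 to compound 4 (0.65 log units; beyond the scatter), and this is the first pair where the chain stays the same and only that hydrogen changes. The earlier steps shown here from compound 2 changed the chain as well as filling the nitrogen, so they could not separate the two changes; here the second chain alone lowers the number, beyond the scatter. Compounds 3, 1 and 4 now form one group, each within the scatter of the next, so diisopropylamino, dipentylamino and dihexylamino are not told apart at this position, while compound 2, the only one with a hydrogen on that nitrogen, stands apart at the higher number.

From the compounds shown here alone, that contrast rests on a single compound with a hydrogen on the nitrogen, so it remains open whether a shorter chain such as butyl or a longer chain such as octyl would show the same step when a second copy is added. Also open, going by these compounds, is how a ring amine such as piperidine, or a chain ending in a carboxylic acid, would behave on the sulfonyl sulfur. Nothing shown here gives a reason for the step.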